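Ring Size of the Chain Amine and Cytotoxic Potency

The compounds below may be only part of what the source reports. "The series", "measured", "known", "first", "only" and "open" are said of these compounds alone.

Three compounds have been measured in a functional assay on A549 cells (Homo sapiens) for cytotoxicity, read by WST assay, with a stated time of 72 h; on this read-out higher numbers stand for weaker inhibition and lower numbers for stronger inhibition:

Compound 1, `COc1cc2c(Nc3nc4ccc(C(=O)Nc5c(C)cccc5Cl)cc4s3)ncnc2cc1OCCCN1CCCC1`: 38600 nM
Compound 2, `COc1cc2c(Nc3nc4ccc(C(=O)Nc5c(C)cccc5Cl)cc4s3)ncnc2cc1OCCCN1CCCCC1`: 12800 nM
Compound 3, `COc1cc2c(Nc3nc4ccc(C(=O)Nc5c(C)cc(C)cc5C)cc4s3)ncnc2cc1OCCCN1CCCCC1`: 10300 nM

In this assay the pair compound 2 and compound 1 shows one change, (pyrrolidin-1-yl in place of piperidin-1-yl on a saturated chain carbon, three bonds along the chain from an oxygen on an aromatic ring), and that change made a 3.0-fold higher number from compound 2 to compound 1 (0.48 log units; beyond the scatter). Compound 3 differs from compound 2 in its core only by 2,4,6-trimethylphenyl in place of 2-chloro-6-methylphenyl on an amide-type nitrogen, and that change made a 1.2-fold lower number from compound 2 to compound 3 (0.09 log units; within the scatter), so compound 2 and compound 3 are treated here as alike.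

Compound 4, `COc1cc2c(Nc3nc4ccc(C(=O)Nc5c(C)cc(C)cc5C)cc4s3)ncnc2cc1OCCCN1CCCC1`, has not yet been measured in this assay. It differs from compound 3 by pyrrolidin-1-yl in place of piperidin-1-yl on a saturated chain carbon, three bonds along the chain from an oxygen on an aromatic ring, the same change at the same place as from compound 2 to compound 1. Going by the values given here, the expectation for compound 4 rests on that single measured precedent: compound 3 is expected to move to compound 4 by a 3.0-fold higher number from compound 3 to compound 4 (0.48 log units; beyond the scatter), set beside the measured 3.0-fold higher number from compound 2 to compound 1 (0.48 log units; beyond the scatter), because a 3.0-fold higher number from compound 2 to compound 1 (0.48 log units; beyond the scatter) is the only instance of this change with a number. Compound 4 is therefore estimated at 31000 nM, with an expected range from 15000 nM to 65000 nM.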

Compound 4, half-maximal inhibitory concentration: 8900 nM
The estimate for compound 4 lay 3.5-fold (0.54 log units) above the measured number; measured number outside the range, below it.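

In this assay, the change from piperidin-1-yl to pyrrolidin-1-yl did not carry from the 2-chloro-6-methylphenyl amide to the 2,4,6-trimethylphenyl amide, where it gave a 1.2-fold lower number from compound 3 to compound 4 (0.06 log units; within the scatter): the same change on two cores in this assay, a 3.0-fold higher number (0.48 log units; beyond the scatter) from compound 2 to compound 1 and a 1.2-fold lower number (0.06 log units; within the scatter) from compound 3 to compound 4, 3.5-fold (0.54 log units) apart, beyond the scatter of two such steps Read the other way, the change from 2-chloro-6-methylphenyl to 2,4,6-trimethylphenyl depended on the chain amine, giving a 4.3-fold lower number from compound 1 to compound 4 (0.64 log units; beyond the scatter) with pyrrolidin-1-yl on the chain: the same change on two cores in this assay, a 1.2-fold lower number (0.09 log units; within the scatter) from compound 2 to compound 3 and a 4.3-fold lower number (0.64 log units; beyond the scatter) from compound 1 to compound 4, 3.5-fold (0.54 log units) apart, beyond the scatter of two such steps Across these four compounds, then, the two changes do not add up independently, but this rests on a single set of two cores and does not show which core is the exception or why the steps differ.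

From the compounds shown here alone, it remains open how the amine change behaves on other amides, such as an unsubstituted phenyl amide. Going by these compounds, it also remains open whether other chain amines, such as morpholin-4-yl or dimethylamino, or a longer chain between the oxygen and the amine, would follow the pattern of the first core or the second.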